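The source may hold more compounds than are shown below. What is called first, only, known or untested is meant among the compounds shown, and "the series" means these compounds.

Measured so far:
compound 1, `Cc1cccc(S(=O)(=O)NCc2ccc(CNC(=O)c3ccc(CNc4ncccn4)cc3)cc2)c1`: 100 nM
compound 2, `O=C(NCc1ccc(CNS(=O)(=O)c2ccc(Cl)cc2)cc1)c1ccc(CNc2ncccn2)cc1`: 100 nM

In an assay on MDA-MB-231 cells for binding affinity to C-X-C chemokine receptor type 4 (Homo sapiens), read by microscopy, with stated times of 10 min and 30 min (a higher number here means that more compound is needed for the effect, a lower number that less compound is needed), compound 1 gives 100 nM and compound 2 gives 100 nM. Within the data shown here, the single measured step, no change at the digits printed from compound 1 to compound 2 (within the scatter), exchanges one substituted phenyl on the sulfonyl sulfur for another and leaves the read-out unchanged within the scatter. Compound 2 therefore stands level with compound 1, with no measured neighbour that differs from it.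

Compound 3, `O=C(NCc1ccc(CNS(=O)(=O)c2ccc([N+](=O)[O-])cc2)cc1)c1ccc(CNc2ncccn2)cc1`, has not yet been measured. It differs from compound 2 by nitro in place of chloro on an aromatic carbon. Among the measured compounds shown here, the only step that bears on this change is the one that also alters the substitution of the phenyl on the sulfonyl sulfur: it was flat within the scatter. On that basis the exchange of the ring substituent is expected to leave the read-out in this assay essentially where compound 2 sits, with no change at the digits printed from compound 2 to compound 3 (within the scatter) expected to be no change beyond the scatter. Compound 3 is therefore estimated at 100 nM in this assay, with an expected range from 40 nM to 250 nM.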

Compound 3, effective concentration (reported as EC, without a stated level of effect): 1000 nM
The estimate for compound 3 lay 10-fold (1.00 log units) below the measured number; measured number outside the range, above it.
By their numbers in this assay, from the lowest: compounds 1 and 2 (each within the scatter of the next); then compound 3.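

In this assay, the change from 4-chlorophenyl to 4-nitrophenyl on the sulfonyl sulfur gives a 10-fold higher number from compound 2 to compound 3 (1.00 log units; beyond the scatter), and the exchange of 3-methylphenyl for 4-nitrophenyl gives the matching a 10-fold higher number from compound 1 to compound 3 (1.00 log units; beyond the scatter). The phenyl on the sulfonyl sulfur is therefore not indifferent to what it carries: the flat step between compound 1 and compound 2 covered only the 3-methylphenyl and 4-chlorophenyl groups, and it does not extend to nitro, which here brings a number beyond the scatter of both earlier compounds. No measurement available here bears on why nitro differs from chloro or methyl in this series.

Still open, on these data alone, is whether this rise is specific to nitro or would also appear with a nitrile, a carboxylic acid or an amine in its place on the same aromatic carbon. The compounds shown also leave open whether a methoxy group or a plain unsubstituted phenyl would stay level with compound 1 and compound 2 or move toward compound 3.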